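A Phenyl for a Butyl: Expected Solubility of Compound 4

The source may report more compounds than this note shows. Statements on the series, on what has been measured and on what is new or still open speak of the compounds shown alone.

Of the compounds shown here, three on a shared core have been measured in a physicochemical assay for solubility, at pH 7.4; a lower number here means a less soluble compound, a higher number a more soluble compound. In this assay compound 1 `OCCNc1nc(NCc2ccco2)c2ccccc2n1` gives <= 20000 nM, which is a limit of the assay and not a number. In this assay compound 2 `CCCCNc1nc(NCCCC)c2ccccc2n1` gives <= 10000 nM, again only a limit. In this assay compound 3 `CCCCNc1nc(NCc2ccccc2)c2ccccc2n1` gives <= 10000 nM, also a limit rather than a number. Compound 3 therefore stands at the limit of <= 10000 nM in this assay, at which 2 of the 3 values shown sit. Compound 1 stands at the limit of <= 20000 nM in this assay, at which 1 of the 3 values shown sits. Within the data shown here, the only measured step between neighbouring structures, a step that the two limits leave unreadable from compound 2 to compound 3, cannot be sized, since both of its ends are limits. Compound 4 `c1ccc(CNc2nc(Nc3ccccc3)nc3ccccc23)cc1` differs from compound 3 by phenyl in place of butyl on a nitrogen on an aromatic ring. Among the measured compounds shown here, no measured step gives a readable size for a change of this kind, so nothing beyond the scatter can be predicted from the data. Compound 4 is expected to stay near that limit, and the step that the limit leaves unreadable from compound 3 to compound 4 is expected to lie within the scatter. Compound 4 is estimated at 5000 nM, with a range from 500 nM to 10000 nM.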

Compound 4, solubility: <= 5000 nM
Compound 4: only a limit was reported; the forecaster's own chance of this, stated with the estimate: 80%; the middle value lies on the limit itself.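

In this assay compound 3 and compound 4 both carry only limits of the assay and not numbers, and the step between them cannot be read. The compounds shown leave open whether phenyl in place of butyl on a nitrogen on an aromatic ring shifts the read-out at all.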